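This account rests on a few compounds, and the source may have more. Where it says the series, first, only, none or still open, it means among the compounds named here.

Three amides built on a shared core have so far been tested in a functional assay on MCF7 cells (Homo sapiens) for inhibition, read by MTT assay; a lower number here means a stronger inhibitor, a higher number a weaker inhibitor. Compound 1 `COc1cc2ncnc(Nc3ccc(NC(=O)c4ccc(F)cc4)cc3)c2cc1OC` gives 27000 nM, compound 2 `COc1cc2ncnc(Nc3ccc(NC(=O)c4ccccc4Cl)cc3)c2cc1OC` gives 36000 nM, and compound 3 `COc1cc2ncnc(Nc3ccc(NC(=O)c4cccc(Cl)c4)cc3)c2cc1OC` gives 18000 nM. Compound 3 therefore stands level with the other two, as its steps to both lie within the scatter.

Compound 4 `COc1cc2ncnc(Nc3ccc(NC(=O)c4ccc(I)cc4)cc3)c2cc1OC` has 4-iodophenyl in place of 3-chlorophenyl on a carbonyl carbon. Among the compounds with values here, no compound carrying iodine has been measured, so the best guide is the other halogen-bearing rings at this same place. These gave a 1.3-fold higher number from compound 1 to compound 2 (0.12 log units; within the scatter), a 1.5-fold lower number from compound 1 to compound 3 (0.18 log units; within the scatter) and a 2.0-fold lower number from compound 2 to compound 3 (0.30 log units; within the scatter). Going by these compounds, none of these steps exceeds the scatter, so no step beyond the scatter is expected in this assay, though iodine remains untested here. The expected change is a 1.3-fold higher number from compound 3 to compound 4 (0.12 log units; within the scatter). For compound 4 the estimated value is 24000 nM, with an expected range from 10000 nM to 55000 nM.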

Compound 4, half-maximal inhibitory concentration: 48000 nM
For compound 4 the middle estimate is 2.0-fold (0.30 log units) below the measured one, and the stated range covers the measured number.
By their numbers in this assay, from the lowest: compounds 3, 1, 2 and 4 (each within the scatter of the next, the first and the last beyond it).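

In this assay, this place on the carbonyl carbon now gives its first step beyond the scatter (from 3-chlorophenyl to 4-iodophenyl: a 2.7-fold higher number from compound 3 to compound 4 (0.43 log units; beyond the scatter)). The other two new steps stay within the scatter (a 1.3-fold higher number from compound 2 to compound 4 (0.12 log units; within the scatter) and, for iodo in place of fluoro on an aromatic carbon, a 1.8-fold higher number from compound 1 to compound 4 (0.25 log units; within the scatter)), so compound 4 separates only from compound 3. No measurement here explains that gap.

The step from compound 3 to compound 4 changes both the halogen and its place on the ring, so these compounds cannot show which of the two matters. Going by these compounds, it also remains open how this assay would respond to a ring carrying an amine or a carboxylic acid, or to a longer alkyl chain on the carbonyl carbon in place of the ring.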